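Shortening the alkylsulfanyl chain on the shared core

This account rests on a few compounds, and the source may have more. Where it says the series, first, only, none or still open, it means among the compounds named here.

Measured so far:
compound 1 `CCCCSC1=N[C@@H](C(=O)OC)[C@@H]2C(=O)N(c3ccccc3)C(=O)[C@H]12`: 82%
compound 2 `CCCSC1=N[C@H](C(=O)OC)[C@@H]2C(=O)N(c3ccccc3)C(=O)[C@H]12`: 86%

In a functional assay for inhibition, tested at 100 uM (on this read-out lower numbers stand for less inhibition and higher numbers for more inhibition at the one concentration tested (going by the name of the read-out)), compound 1 gives 82% and compound 2 gives 86%. The two values lie within the usual scatter of each other, so no order between them is claimed. The two structures are not a single-place pair, and nothing more is read from them.

Compound 3 `CCSC1=N[C@H](C(=O)OC)[C@@H]2C(=O)N(c3ccccc3)C(=O)[C@H]12` is the next member. It differs from compound 2 by hydrogen in place of methyl on a saturated chain carbon, two bonds along the chain from a sulfur. Among the compounds with values here, no measured step of this kind exists. The step of a number 3 percentage points lower from compound 2 to compound 3 (within the scatter) is expected to be small, none beyond the scatter, in either direction. Compound 3 is estimated at 83%, with a range from 68% to 95%.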

Compound 3, a percentage reported as inhibition, at one concentration (the size of the read-out at that concentration, not a potency): 89%
Beside the measured number, compound 3's estimate is 6 percentage points below it; low and high end bracket the measured number.
By their numbers in this assay, from the lowest: compounds 1, 2 and 3 (each within the scatter of the next).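

Hydrogen in place of methyl on a saturated chain carbon, two bonds along the chain from a sulfur (propylsulfanyl to ethylsulfanyl), gives the first single-place step in the series: in this assay the step is a number 3 percentage points higher from compound 2 to compound 3 (within the scatter) and stays inside the scatter. At the one concentration tested, this read-out therefore does not separate these two chains. No available evidence bears on the reason for this result.

Still open, from the compounds shown here alone, is whether a methylsulfanyl group or a chain ending in an amine or a carboxylic acid at this sulfur would keep the read-out in the same range.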